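The source may hold more compounds than are shown below. What is called first, only, known or untested is meant among the compounds shown, and "the series" means these compounds.

Working notes on the series. For the measured compounds named here, compound 1 `COc1ccc(/C=N/NC(=O)c2ccc(O[C@@H]3O[C@H](CO)[C@@H](O)[C@H](O)[C@H]3O)cc2)cc1` and compound 2 `N#Cc1cccc(/C=N/NC(=O)c2ccc(O[C@@H]3O[C@H](CO)[C@@H](O)[C@H](O)[C@H]3O)cc2)c1` are the two compounds measured so far in a functional assay on MDA-MB-231 cells (Homo sapiens) for inhibition, read by MTT assay, with a stated time of 24 h, tested at 100 uM; a lower number here means less inhibition, a higher number more inhibition at the concentration tested (going by the name of the read-out). Compound 1 gives 11.3% and compound 2 gives 6.17%; the step of a number 5.1 percentage points lower from compound 1 to compound 2 (within the scatter) lies within the scatter, so neither is set apart. Compound 3 `O=C(N/N=C/c1ccccc1)c1ccc(O[C@@H]2O[C@H](CO)[C@@H](O)[C@H](O)[C@H]2O)cc1` differs from compound 1 by hydrogen in place of methoxy on an aromatic carbon. Going by the values given here, the only measured step, 3-cyanophenyl in place of 4-methoxyphenyl, alters the same part of the structure and stayed within the scatter, so a step within the scatter is expected here too. The step from compound 1 to compound 3 is expected as a number 2.3 percentage points lower from compound 1 to compound 3 (within the scatter). Compound 3 is estimated at 9%, in a range from 0% to 20%.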

Compound 3, a percentage reported as inhibition, at one concentration (the size of the read-out at that concentration, not a potency): 3.56%
Estimate against measurement, compound 3: 5.4 percentage points above; measured number inside the range.
By their numbers in this assay, from the lowest: compounds 3, 2 and 1 (each within the scatter of the next).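

In this assay, hydrogen in place of methoxy on the aromatic carbon gives a number 7.7 percentage points lower from compound 1 to compound 3 (within the scatter), so removing the substituent altogether does not set the unsubstituted phenyl apart from 4-methoxyphenyl. Hydrogen in place of cyano gives a number 2.6 percentage points lower from compound 2 to compound 3 (within the scatter), so none of the three aryl forms is set apart from the others. Nothing available bears on a reason for these results. Still open, on these data alone, is whether an amine or a carboxylic acid on this ring would give a step beyond the scatter.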